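The compounds below may be only part of what the source reports. "The series", "measured", "known", "first", "only" and "open" are said of these compounds alone.

Compound 1, `CCCc1ccccc1-n1nc(C)c2c1NC(=O)[C@H](C)S[C@@H]2c1ccc(Oc2ccccc2)cc1`, gives 240%.
Compound 2, `Cc1nn(-c2ccccc2C(F)(F)F)c2c1C(c1ccc(Oc3ccccc3)cc1)SC(C)C(=O)N2`, gives 50%.

Both compounds were tested in an assay on isolated protein for agonist activity at Bile acid receptor (Homo sapiens), read by AlphaScreen, with a stated time of 30 min; on this read-out lower numbers stand for smaller maximal responses and higher numbers for larger maximal responses. Compound 2 stands lowest of the two numbers; its nearest neighbour is compound 1, whose value lies higher by a gap beyond the usual scatter. Compound 1 differs from compound 2 in more than one place, so the two values are only a comparison, not a single step.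

The next compound, compound 3, is `Cc1nn(-c2ccccc2Br)c2c1C(c1ccc(Oc3ccccc3)cc1)SC(C)C(=O)N2`. It has not yet been measured in this assay. It differs from compound 2 in one place: bromo in place of trifluoromethyl on an aromatic carbon. Bromo replaces trifluoromethyl on the aromatic carbon that is ortho to a large group.

Going by the values given here, no measured pair shows this exact change, so there is no step to lean on. The expectation for compound 3 is a small rise, a number 40 percentage points higher from compound 2 to compound 3 (beyond the scatter), though a step that stays within the scatter is also plausible. The estimate for compound 3 in this assay is 90%, with a range from 30% to 220%.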

Compound 3, largest response reached (reported as efficacy), in percent of the reference or control that the assay uses: 84%
Compound 3: the middle estimate sits 6 percentage points above what was measured, and the stated range covers the measured number.
By their numbers in this assay, from the lowest: compound 2; then compound 3; then compound 1.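

In this assay, going by these compounds alone, the swap of 2-(trifluoromethyl)phenyl for 2-bromophenyl gives a number 34 percentage points higher from compound 2 to compound 3 (beyond the scatter) and is the first comparison here in which only one group differs, so it shows that this substituent on the aromatic ring can by itself shift the maximal response beyond the usual scatter. The change removes a group of four heavy atoms and puts a single bromine atom in its place, while the count of hydrogen-bond donors and acceptors stays at zero and neither group carries a net charge, so those counts do not separate the two compounds. Nothing measured here shows which difference between the two groups accounts for the step.

Within the data shown here, with only two groups compared at this place, no trend can be drawn, and it remains open where a smaller halogen such as chloro, or a group such as nitrile or methoxy, would fall on this read-out. From the compounds shown here alone, it is also open whether the same swap would give a similar step if another part of the shared core were changed.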